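Dichlorophenyl to chloropyridyl on the ether side chain

A few compounds are considered here, and "the series" means these few. Any claim that something is new, unique, unknown or untested is made for them only; others in the source may bear on it.

Three members of this series have numbers in an assay on isolated protein for activation of cGMP-dependent protein kinase 1 (Homo sapiens), read by ADP-Glo, with stated times of 30 min and 2 h, in the presence of a further agent that is not named here; on this read-out lower numbers stand for an effect already at smaller amounts and higher numbers for an effect only at larger amounts of compound. Compound 1 `Cc1cc(C(=O)O)ccc1CN1CCC[C@H](O[C@H](CO)c2cc(Cl)cc(Cl)c2)[C@@H]1c1ccc(F)cc1` gives 18000 nM in this assay. Compound 2 `OC[C@@H](O[C@H]1CCCN(Cc2ncc[nH]2)[C@H]1c1ccccc1)c1cc(Cl)cc(Cl)c1` gives 47000 nM in this assay. Compound 3 `Cc1cc(C(=O)O)ccc1CN1CCC[C@H](OC(c2cc(Cl)cc(Cl)c2)C(C)O)[C@@H]1c1ccccc1` gives 5300 nM in this assay, the lowest of the three numbers; compound 1 sits beyond the scatter above it and compound 2 further still. Since no two of these compounds differ in only one place, none of these gaps can be tied to a single change.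

Compound 4 `Cc1cc(C(=O)O)ccc1CN1CCC[C@H](O[C@H](CO)c2ccnc(Cl)c2)[C@@H]1c1ccccc1` has not yet been measured in this assay. Compared with compound 3 it carries a group of 10 heavy atoms (7 carbon, 1 nitrogen, 1 oxygen, 1 chlorine; one six-membered aromatic ring with 1 hetero atom) in place of a group of 12 heavy atoms (9 carbon, 1 oxygen, 2 chlorine; one six-membered aromatic ring of carbon only), on an oxygen on a saturated carbon. For the measured compounds named here, no pair already measured shows what such an exchange does in this assay, so the expectation rests on compound 3 alone. A loss of one chlorine together with a ring nitrogen entering is estimated to cost some potency; a step of a 1.9-fold higher number from compound 3 to compound 4 (0.28 log units; within the scatter) is expected, larger than the scatter but not by a wide margin. On that basis compound 4 is expected to give about 10000 nM in this assay, within a range from 3000 nM to 35000 nM.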

Compound 4, half-maximal effective concentration: 50000 nM
Compound 4: middle estimate off by 5.0-fold (0.70 log units), on the low side, outside the stated range (above it).
By their numbers in this assay, from the lowest: compound 3; then compound 1; then compounds 2 and 4 (each within the scatter of the next).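

Replacing the group on an oxygen on a saturated carbon gives a 9.4-fold higher number from compound 3 to compound 4 (0.97 log units; beyond the scatter) in this assay, the only step shown in this series that changes one place, so the number at this position clearly responds to the group carried there. The exchange replaces the whole group, not the aromatic ring alone: the six-membered aromatic ring of carbon only gives way to one with 1 hetero atom, chlorine and carbon counts fall, a hydrogen-bond acceptor is gained, and the entering group has 1 defined stereocentre. Nothing measured here accounts for the size of this step.

For the compounds shown here, the single step cannot apportion the change among the ring nitrogen, the lost chlorine, the remainder of the group and its stereochemistry, and a compound keeping the dichlorinated ring with the side chain of compound 4 would separate the ring from the chain. Also open, going by these compounds, is whether this position accepts other exchanges, such as a pyrimidine ring in place of the aromatic ring or an amine in place of the hydroxyl group on the chain.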